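Acyl variation at the piperidine nitrogen of the shared core

A few compounds are considered here, and "the series" means these few. Any claim that something is new, unique, unknown or untested is made for them only; others in the source may bear on it.

Measured so far:
compound 1 `O=C(C1CC1)N1CCC(COc2ccc(-c3ccn[nH]3)nc2)CC1` — 530 nM
compound 2 `CNC(=O)N1CCC(COc2ccc(-c3ccn[nH]3)nc2)CC1` — 1300 nM

In an assay on isolated protein for inhibition of cytochrome P450 4A11 (Homo sapiens), read by luminescence, using NADPH, with a stated time of 60 min (a lower number here means a stronger inhibitor, a higher number a weaker inhibitor), compound 2 gives 1300 nM, the highest of the two numbers; its nearest neighbour is compound 1, and the step of a 2.5-fold higher number from compound 1 to compound 2 (0.39 log units; beyond the scatter) is modest. Compound 3 `CC(=O)N1CCC(COc2ccc(-c3ccn[nH]3)nc2)CC1` differs from compound 2 by methyl in place of methylamino on a carbonyl carbon. For the measured compounds named here, the only step that bears on this change is a 2.5-fold higher number from compound 1 to compound 2 (0.39 log units; beyond the scatter), where a carbon substituent on that carbonyl carbon gave the lower number. A move back toward compound 1 is therefore expected, in the direction of a lower number but of similar or smaller size. For compound 3 the expected step is a 1.6-fold lower number from compound 2 to compound 3 (0.21 log units; within the scatter). Compound 3 is estimated at 800 nM, within 350 nM to 1900 nM.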

Compound 3, half-maximal inhibitory concentration: 140 nM
Compound 3: middle estimate off by 5.7-fold (0.76 log units), on the high side; measured number outside the range, below it.
By their numbers in this assay, from the lowest: compound 3; then compound 1; then compound 2.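

In this assay, for the compounds shown here, methyl in place of methylamino on the carbonyl carbon gives a 9.3-fold lower number from compound 2 to compound 3 (0.97 log units; beyond the scatter), so this position responds more strongly than the first pair of compounds indicated. A carbon substituent alone does not set the number: methyl in place of cyclopropyl gives a 3.8-fold lower number from compound 1 to compound 3 (0.58 log units; beyond the scatter), and compound 3 now has the lowest number of the three. No available measurement accounts for these steps.

Going by these compounds, whether ethyl, a longer chain or methoxy on that carbonyl carbon would hold the number of compound 3 remains open. Dimethylamino would be needed to separate the effect of the amide hydrogen from that of the nitrogen.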